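This account rests on a few compounds, and the source may have more. Where it says the series, first, only, none or still open, it means among the compounds named here.

Three compounds share one core. Among the measured compounds shown here, in an assay on isolated protein for inhibition of proto-oncogene tyrosine-protein kinase receptor Ret variant V804M (Homo sapiens), read by 33P incorporation, with stated times of 15 min and 40 min (a higher number here means a weaker inhibitor, a lower number a stronger inhibitor), compound 1 `Cc1cc(C)cc(NC(=O)Nc2ccc(Nc3ncnc4c3OCCN4)cc2)c1` gives 971 nM and compound 2 `O=C(Nc1ccc(Nc2ncnc3c2OCCN3)cc1)Nc1cc(Cl)cc(Cl)c1` gives 1300 nM in this assay; the step of a 1.3-fold higher number from compound 1 to compound 2 (0.13 log units; within the scatter) is the only single-point comparison among them. Compound 3 `CC(C)(C)c1cc(NC(=O)Nc2ccc(Nc3ncnc4c3OCCN4)nc2)no1` gives 180 nM in this assay, the lowest of the three numbers, with compound 1 nearest and compound 2 furthest, both gaps beyond the scatter. Compound 4 `Cc1nc(Nc2ncnc3c2OCCN3)ccc1NC(=O)Nc1cc(C(C)(C)C)on1` differs from compound 3 by methyl in place of hydrogen on an aromatic carbon. For the measured compounds named here, no measured step places a methyl on an aromatic carbon of the core-side ring, and the one measured step, a 1.3-fold higher number from compound 1 to compound 2 (0.13 log units; within the scatter), concerns the other end of the molecule and sits within the scatter. No shift beyond the scatter is therefore expected, no change at the digits printed from compound 3 to compound 4 (within the scatter). Compound 4 is estimated in this assay at 180 nM, range 80 nM to 450 nM.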

Compound 4, half-maximal inhibitory concentration: 1110 nM
Beside the measured number, compound 4's estimate is 6.2-fold (0.79 log units) below it; the whole stated range lies below it.
By their numbers in this assay, from the lowest: compound 3; then compounds 1, 4 and 2 (each within the scatter of the next).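

Methyl in place of hydrogen on an aromatic carbon, next to the ring nitrogen and ortho to a large group, gives a 6.2-fold higher number from compound 3 to compound 4 (0.79 log units; beyond the scatter) in this assay, so this position responds to the addition of a single carbon. The earlier step, at the other end of the molecule, stayed within the scatter and said nothing about this site. Nothing available accounts for the shift.

Going by these compounds, it remains open whether the weakening is specific to methyl or extends to other groups on this carbon, such as fluorine, methoxy or an amine. The compounds shown also leave open how a longer chain such as ethyl would read here.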